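The source may report more compounds than this note shows. Statements on the series, on what has been measured and on what is new or still open speak of the compounds shown alone.

Working notes on the chain at the aromatic nitrogen of the shared core. In a functional assay on MCF7 cells (Homo sapiens) for cytotoxicity (a lower number here means that less compound is needed, a higher number that more compound is needed for the effect), compound 1 `CCCCCn1c(Cc2cc(OC)c(OC)c(OC)c2)nc2c(N)nc(F)nc21` gives 286000000 nM. Compound 2 `COCCCn1c(Cc2cc(OC)c(OC)c(OC)c2)nc2c(N)nc(F)nc21` gives 72600000 nM in this assay. Compound 3 `C#CCCn1c(Cc2cc(OC)c(OC)c(OC)c2)nc2c(N)nc(F)nc21` gives 286000000 nM in this assay. Compound 3 thus stands level with compound 1, the pair together above compound 2: no change at the digits printed from compound 1 to compound 3 (within the scatter), while a 3.9-fold higher number from compound 2 to compound 3 (0.60 log units; beyond the scatter). Compound 4 `CC#CCCn1c(Cc2cc(OC)c(OC)c(OC)c2)nc2c(N)nc(F)nc21` differs from compound 3 by methyl in place of hydrogen on a triple-bonded carbon. Among the compounds with values here, no measured step alters the chain at its far end in this way; the nearest, no change at the digits printed from compound 1 to compound 3 (within the scatter), exchanged the whole chain without effect, and a 3.9-fold lower number from compound 1 to compound 2 (0.60 log units; beyond the scatter) concerns a different chain. Hence no step beyond the scatter is expected in this assay. Compound 4 is therefore estimated at 286000000 nM, range 120000000 nM to 650000000 nM. The expected step is no change at the digits printed from compound 3 to compound 4 (within the scatter).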

Compound 4, half-maximal effective concentration: 95500000 nM
The estimate for compound 4 lay 3.0-fold (0.48 log units) above the measured number, outside the stated range (below it).
By their numbers in this assay, from the lowest: compounds 2 and 4 (each within the scatter of the next); then compounds 1 and 3 (each within the scatter of the next).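

In this assay the end of the triple bond proved sensitive to substitution, with methyl in place of hydrogen giving a 3.0-fold lower number from compound 3 to compound 4 (0.48 log units; beyond the scatter), whereas the ethynyl-for-propyl exchange had changed nothing at the digits printed. The pent-3-yn-1-yl chain also separates from the pentyl chain, with a 3.0-fold lower number from compound 1 to compound 4 (0.48 log units; beyond the scatter), and it matches the methoxy-bearing chain, with a 1.3-fold higher number from compound 2 to compound 4 (0.12 log units; within the scatter). No supporting data bear on why the methyl shifts the number. Open, on these data alone, is how a longer chain, an amine or a carboxylic acid at this chain end would read in this assay.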